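The compounds below may be only part of what the source reports. "The series", "measured", "known", "first", "only" and "open" are said of these compounds alone.

Measured compounds:
- compound 1, `CS(=O)(=O)c1ccc(Cc2nnc3n2N=C(c2ccc(-c4ccccc4)cc2)CS3)cc1`: in a functional assay on RAW264.7 cells (Mus musculus) for cytotoxicity, read by MTT assay, with a stated time of 48 h, tested at 12.5 uM (on this read-out higher numbers stand for a stronger effect at the one concentration tested and lower numbers for a weaker effect), compound 1 gives 58.2%
- compound 2, `CS(=O)(=O)c1ccc(Cc2nnc3n2N=C(c2ccc(Cl)cc2Cl)CS3)cc1`: in this assay compound 2 gives 28%

Compound 2 stands lowest of the two numbers in this assay; its nearest neighbour is compound 1, whose value lies higher by a margin beyond the usual scatter. Among the measured compounds shown here, no single-point step between measured compounds is available, so the two values can only be read side by side.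

Compound 3, `Cc1ccc(C2=Nn3c(Cc4ccc(S(C)(=O)=O)cc4)nnc3SC2)cc1`, is not yet measured in this assay. It differs from compound 2 in one place: 4-methylphenyl in place of 2,4-dichlorophenyl on a carbon with a double bond to nitrogen. Nothing measured here shows how a 4-methylphenyl group at this carbon behaves, and compound 1 carries a different aryl group again, so the expectation for compound 3 rests on a wide spread between the two measured values. A small upward step, possibly within the scatter, is expected: a number 7 percentage points higher from compound 2 to compound 3 (within the scatter). Compound 3 is therefore estimated at 35% in this assay, within a range from 15% to 60%.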

Compound 3, a percentage reported as activity, at one concentration (the size of the read-out at that concentration, not a potency): "not active" (no number reported)
For compound 3 the study gives words and no number; there is nothing to compare the estimate with.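

In this assay, among the compounds shown here, compound 3 is reported in words without a number, so no step from compound 2 to compound 3 can be read. Nothing shown bears on this result. The compounds shown leave open how 4-methylphenyl and 2,4-dichlorophenyl compare numerically at this carbon.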